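Swapping the aryl group on a thiophene core

The compounds below may be only part of what the source reports. "The series", "measured", "known", "first", "only" and "open" are said of these compounds alone.

Measured compounds:
- compound 1, `CC(C)(C)Cc1c(-c2ccc(F)cc2)sc(N)c1C(=O)c1ccc(Cl)cc1`: 9%
- compound 2, `COc1ccccc1-c1sc(N)c(C(=O)c2ccc(Cl)cc2)c1CC(C)(C)C`: 1%

In an assay on CHO cells for displacement of a labelled ligand from adenosine receptor A3 (Homo sapiens), read by scintillation counting, tested at 10 uM (a higher number here means more inhibition at the concentration tested (going by the name of the read-out), a lower number less inhibition), compound 1 gives 9%, and compound 2 gives 1%. The two numbers lie within the usual scatter of each other, so compound 2 cannot be told apart from compound 1 on these data: both show little inhibition at the concentration tested. Going by the values given here, the only measured step, a number 8 percentage points lower from compound 1 to compound 2 (within the scatter), exchanges one aryl group for another on the same aromatic carbon of the shared core and leaves the read-out essentially where it was.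

Compound 3, `Cc1ccc(-c2sc(N)c(C(=O)c3ccc(Cl)cc3)c2CC(C)(C)C)cc1`, is not yet measured. It differs from compound 2 as follows: 4-methylphenyl in place of 2-methoxyphenyl on an aromatic carbon. This is the same kind of change as the measured step, another aryl group placed on the same carbon of the shared core. Because the step of a number 8 percentage points lower from compound 1 to compound 2 (within the scatter) stayed within the scatter, no step beyond the scatter is expected in this assay either way, and compound 3 is estimated to give 5%, within -5% to 15%, a step of a number 4 percentage points higher from compound 2 to compound 3 (within the scatter).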

Compound 3, a percentage reported as inhibition, at one concentration (the size of the read-out at that concentration, not a potency): 1%
Beside the measured number, compound 3's estimate is 4 percentage points above it; the measured number falls inside the stated range.
By their numbers in this assay, from the lowest: compounds 2, 3 and 1 (each within the scatter of the next).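

In this assay, the change at this aromatic carbon, next to the ring sulfur, gives no change at the digits printed from compound 2 to compound 3 (within the scatter) even though the 2-methoxyphenyl group carries 1 hydrogen-bond acceptor and the 4-methylphenyl group carries 0, so on these data removing that acceptor leaves the read-out unmoved. Comparing a methyl with a fluoro on the aryl group gives a number 8 percentage points lower from compound 1 to compound 3 (within the scatter) and adds a second single change that stays inside the scatter, which means that all three aryl groups at this position, the 4-fluorophenyl, 2-methoxyphenyl and 4-methylphenyl, cannot be told apart here. No measurement is available that would explain why these numbers stay together.

On these data alone, what remains open is whether a group of a different kind on this same carbon, such as a carboxylic acid, an aminomethyl-substituted phenyl ring or a morpholine, would move the read-out beyond the scatter. The compounds shown also leave open what a longer chain in place of the neopentyl group, or an amide on the amino group, would do to the inhibition at the concentration tested.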